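Swapping an Ethyl for Methylsulfanyl on an Acylguanidine

A few compounds are considered here, and "the series" means these few. Any claim that something is new, unique, unknown or untested is made for them only; others in the source may bear on it.

Of the compounds shown here, three built around a shared acylguanidine-bearing core have been measured in a functional assay for inhibition of sodium/hydrogen exchanger (Oryctolagus cuniculus); on this read-out higher numbers stand for weaker inhibition and lower numbers for stronger inhibition. Compound 1 `CCc1cc(C)c(C(=O)N=C(N)N)cc1S(C)(=O)=O` gives 4.8 nM, the lowest of the three numbers and therefore the strongest inhibition. Compound 2 `Cc1c(C(=O)N=C(N)N)cc(S(C)(=O)=O)c(C)c1C` gives 55 nM, and compound 3 `Cc1cc(Br)c(C(=O)N=C(N)N)cc1S(C)(=O)=O` gives 70 nM; both stand well beyond the usual scatter from compound 1, with compound 2 the nearer of the two and compound 3 the further. Among the compounds with values here, none of these three differs from another in a single place, so no measured step can guide what follows.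

Compound 4 `CSc1cc(C)c(C(=O)N=C(N)N)cc1S(C)(=O)=O` has not yet been measured. It differs from compound 1 in one place: methylsulfanyl in place of ethyl on an aromatic carbon. The group that leaves and the group that enters are of equal size, and the entering one brings a single hydrogen-bond acceptor where the ethyl brought none.

With nothing measured on this exact change, the expectation for compound 4 rests on its closeness in size to compound 1, and the step of a 1.7-fold higher number from compound 1 to compound 4 (0.22 log units; within the scatter) is expected to stay within the scatter, with no clear direction. Compound 4 is estimated at 8 nM in this assay, with a likely range from 2.5 nM to 25 nM.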

Compound 4, half-maximal inhibitory concentration: 6 nM
For compound 4 the middle estimate is 1.3-fold (0.12 log units) above the measured one, and the stated range covers the measured number.
By their numbers in this assay, from the lowest: compounds 1 and 4 (each within the scatter of the next); then compounds 2 and 3 (each within the scatter of the next).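

Going from ethyl to methylsulfanyl gives a 1.3-fold higher number from compound 1 to compound 4 (0.10 log units; within the scatter) in this assay, the first comparison in this series that changes only one place. At this position, on an aromatic carbon ortho to a methylsulfonyl group, the two groups therefore cannot be told apart by this read-out, even though methylsulfanyl carries a sulfur atom and a hydrogen-bond acceptor that ethyl lacks. Nothing in the data shown offers a measured reason for this closeness.

The compounds shown do not tell whether the same position would stay within the scatter with a longer chain such as propyl, with a methoxy group, or with an amine or a carboxylic acid, any of which would show how far the tolerance seen with this one pair of groups extends. This is also a single swap in a single setting, so they leave open whether methylsulfanyl and ethyl would still match if the methyl group or the methylsulfonyl group on the shared core were changed.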